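The source may report more compounds than this note shows. Statements on the series, on what has been measured and on what is new or still open speak of the compounds shown alone.

Working notes on the series. In a functional assay on HepG2 cells (Homo sapiens) for antiproliferative activity, read by MTT assay, with a stated time of 48 h (a lower number here means a stronger inhibitor, a higher number a weaker inhibitor), compound 1 `C#Cc1cccc(Nc2ncnc3cc(NC(=O)/C=C/c4ccccc4)sc23)c1` gives 15400 nM as its reading, compound 2 `O=C(/C=C/c1ccccc1)Nc1cc2ncnc(Nc3ccc(F)c(Cl)c3)c2s1` gives 10600 nM and compound 3 `COc1ccc(/C=C/C(=O)Nc2cc3ncnc(Nc4ccc(F)c(Cl)c4)c3s2)cc1` gives 13900 nM under the same conditions. Compound 2 stands within the scatter of both compound 1 and compound 3, so these three sit at one level and cannot be ranked.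

Compound 4 `O=C(/C=C/c1ccccc1)Nc1cc2ncnc(Nc3ccc(Cl)c(Cl)c3)c2s1` differs from compound 2 by chloro in place of fluoro on an aromatic carbon, which turns 3-chloro-4-fluorophenyl into 3,4-dichlorophenyl. For the measured compounds named here, two measured steps bear on this. Placing 3-chloro-4-fluorophenyl where 3-ethynylphenyl stood gives a 1.5-fold lower number from compound 1 to compound 2 (0.16 log units; within the scatter) at the same group, methoxy in place of hydrogen gives a 1.3-fold higher number from compound 2 to compound 3 (0.12 log units; within the scatter) elsewhere in the molecule, and neither leaves the scatter. A step beyond the scatter is therefore not expected in this assay, and no direction is favoured. The estimated change is a 1.0-fold higher number from compound 2 to compound 4 (0.02 log units; within the scatter) and is expected to stay within the scatter. Compound 4 is expected at 11000 nM as the estimate, with an estimated range from 6000 nM to 20000 nM for repeated measurements.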

Compound 4, half-maximal inhibitory concentration: 13400 nM
Compound 4: middle estimate off by 1.2-fold (0.09 log units), on the low side; the range from low to high includes it.
By their numbers in this assay, from the lowest: compounds 2, 4, 3 and 1 (each within the scatter of the next).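

In this assay, for the compounds shown here, chloro in place of fluoro, at the place para to a large group and ortho to a chloro group, gives a 1.3-fold higher number from compound 2 to compound 4 (0.10 log units; within the scatter) and so tests this halogen directly for the first time, with no separable effect on the reading. The 3,4-dichlorophenyl group also stays level with the 3-ethynylphenyl group, with a 1.1-fold lower number from compound 1 to compound 4 (0.06 log units; within the scatter) as the step, so this comparison of groups on the nitrogen likewise gives no ranking. Nothing measured here offers a cause for either reading.

From the compounds shown here alone, whether an amine or a carboxylic acid at this same place would move the reading beyond the scatter stays open. Also open, going by these compounds, is whether any change on this ring can separate compounds, since the halogen exchange at this place has not done so.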